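Removing the pendant ring: what stability may be expected

A few compounds are considered here, and "the series" means these few. Any claim that something is new, unique, unknown or untested is made for them only; others in the source may bear on it.

Measured compounds:
- compound 1, `CCCCc1nc(=O)c(S(=O)(=O)c2ccc(-c3ccc(F)cc3)cc2)c(O)n1-c1c(OC)cccc1OC`, 47%
- compound 2, `CCCCc1nc(=O)c(S(=O)(=O)c2ccc(-c3ccc(F)nc3)cc2)c(O)n1-c1c(OC)cccc1OC`, 69%
- compound 3, `CCCCc1nc(=O)c(S(=O)(=O)c2ccc(-n3cc(Cl)ccc3=O)cc2)c(O)n1-c1c(OC)cccc1OC`, 100%

These three compounds share one core and differ only in the ring attached to the sulfonyl-bearing benzene. In an ADME assay on microsomes from liver (Mus musculus) for metabolic stability, using NADPH, with a stated time of 10 min (on this read-out lower numbers stand for a less stable compound and higher numbers for a more stable compound), compound 3 stands highest of the three: the step of a number 31 percentage points higher from compound 2 to compound 3 (beyond the scatter) is large, and the step of a number 53 percentage points higher from compound 1 to compound 3 (beyond the scatter) is larger still. Between the two lower compounds, the step of a number 22 percentage points higher from compound 1 to compound 2 (beyond the scatter) is modest but beyond the scatter.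

Compound 4, `CCCCc1nc(=O)c(S(=O)(=O)c2ccccc2)c(O)n1-c1c(OC)cccc1OC`, is not yet measured. Compared with compound 3 it carries a hydrogen atom in place of a group of 8 heavy atoms (5 carbon, 1 nitrogen, 1 oxygen, 1 chlorine; one six-membered aromatic ring with 1 hetero atom), on an aromatic carbon. The pendant ring is therefore gone altogether, leaving a bare benzene on the sulfonyl group.

All three measured steps concern the identity of that pendant ring, and each of them moved the read-out beyond the scatter, so the ring clearly matters to this assay. None of them, however, removes the ring entirely, so the measured data offer no direct guide to compound 4. Since every variant of the ring sat below the pyridinone of compound 3, and compound 1 gives 47%, compound 4 is expected to fall below compound 3, by an estimated step of a number 45 percentage points lower from compound 3 to compound 4 (beyond the scatter). The estimated value for compound 4 is 55%, within a range of 25% to 90%.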

Compound 4, percent of the compound remaining: 79%
For compound 4 the middle estimate is 24 percentage points below the measured one, and the stated range covers the measured number.
By their numbers in this assay, from the lowest: compound 1; then compounds 2 and 4 (each within the scatter of the next); then compound 3.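

Within the data shown here, the bare benzene shows what the earlier compounds could not: how each pendant ring compares with no ring at all on this aromatic carbon, and the rings do not all fall on the same side in this assay. Replacing 4-fluorophenyl with hydrogen gives a number 32 percentage points higher from compound 1 to compound 4 (beyond the scatter), whereas losing the ring of compound 3 gives a number 21 percentage points lower from compound 3 to compound 4 (beyond the scatter), so one ring sits under the ring-free compound and the other over it, while for 6-fluoropyridin-3-yl the change gives a number 10 percentage points higher from compound 2 to compound 4 (within the scatter), which leaves that ring and hydrogen indistinguishable here. Nothing among the data shown explains why these rings part ways in this manner.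

On these data alone, whether a single small group on the aromatic carbon para to a large group, such as methoxy or an amine, would read like compound 4 or move towards compound 1 or compound 3 remains open. Also open, as far as these compounds go, is whether the high number of compound 3 depends on its chlorine, or would hold with hydrogen or a methyl group in its place on that ring.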